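Replacing the aryl group on the double-bonded ring carbon

The compounds below may be only part of what the source reports. "The series", "measured", "known", "first", "only" and "open" are said of these compounds alone.

Measured so far:
compound 1, `C[C@@H](O[C@H]1CN2C(=O)C=C(c3ccccc3)CC2[C@@H]1c1ccc(F)cc1)c1cc(C(F)(F)F)cc(C(F)(F)F)c1` — 0.93 nM
compound 2, `Cc1cc(C2=CC(=O)N3C[C@H](O[C@H](C)c4cc(C(F)(F)F)cc(C(F)(F)F)c4)[C@@H](c4ccc(F)cc4)C3C2)ccn1` — 0.51 nM

In an assay on CHO cells for displacement of a labelled ligand from Substance-P receptor (Homo sapiens) (on this read-out lower numbers stand for stronger inhibition and higher numbers for weaker inhibition), compound 2 gives 0.51 nM, the lower of the two measured values, and compound 1 gives 0.93 nM. Going by the values given here, the single measured step is a 1.8-fold lower number from compound 1 to compound 2 (0.26 log units; within the scatter), so both compounds stand within the scatter of each other. Compound 3 `C[C@@H](O[C@H]1CN2C(=O)C=C(C3=CCOCC3)CC2[C@@H]1c1ccc(F)cc1)c1cc(C(F)(F)F)cc(C(F)(F)F)c1` differs from compound 2 in one place: a group of 6 heavy atoms (5 carbon, 1 oxygen; one six-membered non-aromatic ring with 1 hetero atom) in place of a group of 7 heavy atoms (6 carbon, 1 nitrogen; one six-membered aromatic ring with 1 hetero atom), on a double-bonded ring carbon. Among the compounds with values here, the one step available exchanges a six-membered aromatic ring for another six-membered aromatic ring at this position and therefore says little about a six-membered non-aromatic ring with one hetero atom in the same place. Within the data shown here, no measured step bears directly on the new group, and the unchanged shared core carries most of the expectation. Compound 3 is expected at 1.5 nM, between 0.5 nM and 5 nM, which amounts to an expected step of a 2.9-fold higher number from compound 2 to compound 3 (0.47 log units; beyond the scatter).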

Compound 3, half-maximal inhibitory concentration: 0.18 nM
Compound 3: middle estimate off by 8.3-fold (0.92 log units), on the high side; the measured number lies below the stated range.
By their numbers in this assay, from the lowest: compound 3; then compounds 2 and 1 (each within the scatter of the next).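

In this assay this position on the double-bonded ring carbon does not depend on an aromatic ring: the non-aromatic six-membered ring with one ring oxygen gives a 2.8-fold lower number from compound 2 to compound 3 (0.45 log units; beyond the scatter) and also a 5.2-fold lower number from compound 1 to compound 3 (0.71 log units; beyond the scatter) and both steps lie beyond the scatter. The earlier exchange of one aromatic ring for another gave only a 1.8-fold lower number from compound 1 to compound 2 (0.26 log units; within the scatter) and stayed within the scatter, so only the change of ring type separates compounds at this position. Nothing available accounts for the gain.

The compounds shown do not separate the contribution of the ring oxygen from that of the ring double bond, since neither a carbon-only cyclohexenyl ring nor a saturated tetrahydropyranyl ring appears among them. As far as these compounds go, how a ring amine or an open ether chain would behave on this carbon also remains open.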